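Methylamino for Methoxy on a Benzofuran-Bearing Nucleoside

A few compounds are considered here, and "the series" means these few. Any claim that something is new, unique, unknown or untested is made for them only; others in the source may bear on it.

Compound 1 `C#Cc1cn([C@@H]2O[C@H](CO)[C@@H](O)[C@H]2O)c2ncnc(NC)c12`: in a functional assay on HeLa S3 cells (Homo sapiens) for antiproliferative activity, read by XTT assay, with a stated time of 72 h (on this read-out higher numbers stand for weaker inhibition and lower numbers for stronger inhibition), compound 1 gives > 20000 nM, which is a limit of the assay, not a number.
Compound 2 `C#Cc1cn([C@@H]2O[C@H](CO)[C@@H](O)[C@H]2O)c2ncnc(OC)c12`: in this assay compound 2 gives 1730 nM.
Compound 3 `COc1ncnc2c1c(-c1cc3ccccc3o1)cn2[C@@H]1O[C@H](CO)[C@@H](O)[C@H]1O`: in this assay compound 3 gives 9240 nM.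

Two changes connect these. The first is methylamino in place of methoxy on an aromatic carbon; it gives an at least 11-fold higher number from compound 2 to compound 1 (1.06 log units; beyond the scatter), and the size is only a lower bound because of the limit of > 20000 nM in this assay, at which 1 of the 3 values shown sits. The second is 1-benzofuran-2-yl in place of ethynyl on an aromatic carbon; it gives a 5.3-fold higher number from compound 2 to compound 3 (0.73 log units; beyond the scatter).

Compound 4 `CNc1ncnc2c1c(-c1cc3ccccc3o1)cn2[C@@H]1O[C@H](CO)[C@@H](O)[C@H]1O` is not yet measured. It differs from compound 3 by methylamino in place of methoxy on an aromatic carbon, the same change already seen from compound 2 to compound 1, at the same place. Since compound 3 already stands at 9240 nM, and the earlier step of this change was an at least 11-fold higher number from compound 2 to compound 1 (1.06 log units; beyond the scatter), the expected outcome is a step of a 6.5-fold higher number from compound 3 to compound 4 (0.81 log units; beyond the scatter). The estimated value for compound 4 in this assay is 60000 nM, between 20000 nM and 200000 nM.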

Compound 4, half-maximal inhibitory concentration: > 20000 nM
Compound 4 ended at the assay's limit; the forecaster's own chance of this, stated with the estimate: 85%; the middle value lies beyond the limit too.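

In this assay compound 4 gives > 20000 nM, which is a limit of the assay and not a number. Methylamino in place of methoxy gives an at least 2.1-fold higher number from compound 3 to compound 4 (0.33 log units; beyond the scatter), so the direction of the change carries from the core of compound 2 to the core of compound 3: the same change on two cores in this assay, an at least 11-fold higher number (1.06 log units; beyond the scatter) from compound 2 to compound 1 and an at least 2.1-fold higher number (0.33 log units; beyond the scatter) from compound 3 to compound 4; the limit leaves it open whether they differ. From the compounds shown here alone, the true size of the change stays unknown on both cores, and the step between compound 1 and compound 4 cannot be read, because the values of both compounds are limits: the limit of > 20000 nM in this assay, at which 2 of the 4 values shown sit.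

At the place of this change, the compounds shown carry only methoxy and methylamino, so it stays open how an ethoxy group, a free amino group or a dimethylamino group would behave on either core. Going by these compounds, at the other place of difference they carry only ethynyl and 1-benzofuran-2-yl, so it also stays open whether the same direction would hold with a phenyl ring or a longer alkyne chain there.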